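A few compounds are considered here, and "the series" means these few. Any claim that something is new, unique, unknown or untested is made for them only; others in the source may bear on it.

Compounds measured so far in a toxicity assay on HeLa cells (Homo sapiens) for cytotoxicity, read by MTT assay, with a stated time of 24 h; on this read-out lower numbers stand for stronger inhibition and higher numbers for weaker inhibition: compound 1 `COc1ccccc1N1CCN(C(=S)SCC(O)Cn2c([N+](=O)[O-])cnc2C)CC1` gives > 5000000 nM; compound 2 `Cc1nc([N+](=O)[O-])cn1CC(O)CSC(=S)N1CCN(c2cccc(Cl)c2Cl)CC1` gives 724000 nM; compound 3 `Cc1nc([N+](=O)[O-])cn1CC(O)CSC(=S)N1CCN(c2ccccc2)CC1` gives > 5000000 nM.

The value of compound 3 is a limit of this assay, not a number. The value of compound 1 is likewise a limit. Compound 2 is the only one of the three with a number in this assay. Among the measured compounds shown here, the one step among the measured compounds runs an at least 6.9-fold higher number from compound 2 to compound 3 (0.83 log units; beyond the scatter), so the move to the plain phenyl ring took the value out to the limit where the limit of > 5000000 nM in this assay, at which 2 of the 3 values shown sit, describes two of the three results.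

Compound 4 `COc1ccccc1N1CCN(C(=S)SCC(O)Cn2cc([N+](=O)[O-])nc2C)CC1` has not yet been measured. It differs from compound 3 by methoxy in place of hydrogen on an aromatic carbon. For the measured compounds named here, no measured step covers this change directly; the closest guide is compound 1, which also bears a 2-methoxyphenyl group on a closely related core and sits at the limit in this assay. The step from compound 2 to compound 3 shows that changing the aryl group can move the value by at least a modest amount, but here both neighbours sit at the limit. Compound 4 is therefore expected to sit at or near the limit, a step that the limit leaves unreadable from compound 3 to compound 4 in this assay, with no change beyond the scatter. The estimate for compound 4 is 6000000 nM, between 2000000 nM and 20000000 nM.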

Compound 4, half-maximal inhibitory concentration: > 5000000 nM
Compound 4 gave a limit, no number (the forecaster's own chance of this, stated with the estimate: 75%); the middle value does not contradict the limit.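

In this assay, 2-methoxyphenyl in place of 2,3-dichlorophenyl on the amine nitrogen in the ring gives an at least 6.9-fold higher number from compound 2 to compound 4 (0.83 log units; beyond the scatter). Among the compounds shown here, on this shared core, the plain phenyl of compound 3 is therefore no longer the only aryl group that leaves the number of compound 2 behind. Compound 4 is itself a limit, so compound 2 is the only compound shown with a number, and the other three stand together: the limit of > 5000000 nM in this assay, at which 3 of the 4 values shown sit.

The steps from compound 3 to compound 4 and from compound 1 to compound 4 cannot be read, so neither the methoxy group nor the move of the nitro group on the imidazole can be given any size here. The compounds shown leave open whether a single chloro group on the phenyl ring, or a bromo or a methyl group in its place, would bring a number into range as compound 2 does with 724000 nM.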